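The source may hold more compounds than are shown below. What is called first, only, known or untested is meant among the compounds shown, and "the series" means these compounds.

Compounds measured in an ADME assay on HEK293 cells (Homo sapiens) for cytotoxicity, read by resazurin assay, with a stated time of 48 h; on this read-out higher numbers stand for lower toxicity in this test and lower numbers for higher toxicity in this test:
compound 1 `Cc1ccccc1S(=O)(=O)Nc1ccc2oc(-c3ccccc3)nc2c1`, 57000 nM
compound 2 `COc1cccc(S(=O)(=O)Nc2ccc3oc(-c4ccccc4)nc3c2)c1`, 63000 nM
compound 3 `O=[N+]([O-])c1cc(S(=O)(=O)Nc2ccc3oc(-c4ccccc4)nc3c2)ccc1Cl`, 90000 nM

In this assay compound 3 gives the highest of the three numbers, yet its gaps to compound 2 and to compound 1 are both within the scatter. Among the measured compounds shown here, the one single-place step among the measured compounds, a 1.1-fold higher number from compound 1 to compound 2 (0.04 log units; within the scatter), is likewise within the scatter and concerns only the aryl group on the sulfonyl sulfur. Compound 4 `O=S(=O)(Nc1ccc2oc(-c3ccccc3)nc2c1)c1ccc(Cl)cc1` differs from compound 3 by hydrogen in place of nitro on an aromatic carbon. For the measured compounds named here, no measured step touches a nitro group, so the expectation rests only on how tightly the three numbers cluster: no step beyond the scatter is expected. Compound 4 is estimated at 80000 nM, between 40000 nM and 160000 nM. The expected step is a 1.1-fold lower number from compound 3 to compound 4 (0.05 log units; within the scatter).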

Compound 4, half-maximal cytotoxic concentration: 65000 nM
Compound 4: the middle estimate sits 1.2-fold (0.09 log units) above what was measured; measured number inside the range.
By their numbers in this assay, from the lowest: compounds 1, 2, 4 and 3 (each within the scatter of the next).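

In this assay, hydrogen in place of nitro on an aromatic carbon ortho to a chloro group is a step within the scatter (a 1.4-fold lower number from compound 3 to compound 4 (0.14 log units; within the scatter)), the first step shown at this position. The 4-chlorophenyl group on the sulfonyl sulfur likewise lies within the scatter of the 3-methoxyphenyl group (a 1.0-fold higher number from compound 2 to compound 4 (0.01 log units; within the scatter)) and of the 2-methylphenyl group (a 1.1-fold higher number from compound 1 to compound 4 (0.06 log units; within the scatter)). No supporting data bear on these results. From the compounds shown here alone, whether an amine or a carboxylic acid at this position, or a change elsewhere on the shared core, would give a step beyond the scatter remains open.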